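The source may report more compounds than this note shows. Statements on the series, on what has been measured and on what is new or still open speak of the compounds shown alone.

In a functional assay on HT-29 cells (Homo sapiens) for inhibition, read by MTT assay, with a stated time of 2 days (a higher number here means a weaker inhibitor, a lower number a stronger inhibitor), compound 1 `Oc1cccc(/C=C/c2cccc(O)c2)c1` gives 25.9 ug/mL while compound 2 `COc1cccc(/C=C/c2ccccc2O)c1` gives 26 ug/mL and compound 3 `Nc1cccc(/C=C/c2cccc(O)c2)c1` gives 43 ug/mL in this read-out, which places compound 3 within the scatter of both others. Compound 4 `COc1cccc(/C=C/c2cccc(N)c2)c1` differs from compound 3 by one change methyl in place of hydrogen on an oxygen on an aromatic ring in the form of methyl in place of hydrogen on an oxygen on an aromatic ring, or hydroxy to methoxy. Among the measured compounds shown here, no measured step covers this change. For the measured compounds named here, the only step at hand is a 1.7-fold higher number from compound 1 to compound 3 (0.22 log units; within the scatter) for amino in place of hydroxy on an aromatic carbon and it lies within the scatter. Compound 2 also carries methoxy and its value stays within the scatter of the others. A step beyond the scatter in this assay is therefore not expected, and the estimated 1.3-fold lower number from compound 3 to compound 4 (0.11 log units; within the scatter) stays inside it. Compound 4 is estimated at 33 ug/mL with an expected range from 14 ug/mL to 75 ug/mL for this compound.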

Compound 4, half-maximal inhibitory concentration: 19.6 ug/mL
Compound 4: the middle estimate sits 1.7-fold (0.23 log units) above what was measured; the range from low to high includes it.
By their numbers in this assay, from the lowest: compounds 4, 1, 2 and 3 (each within the scatter of the next, the first and the last beyond it).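

In this assay, methyl in place of hydrogen on an oxygen on an aromatic ring, hydroxy to methoxy, gives a 2.2-fold lower number from compound 3 to compound 4 (0.34 log units; beyond the scatter). Among the compounds shown here, this modest step is the first single change here to pass beyond the scatter, since the only earlier step, amino in place of hydroxy, stayed within it. No available evidence bears on why this step occurs. The compounds shown leave open whether a longer chain on this oxygen, such as ethoxy, would go further. They also leave open whether a carboxylic acid there would keep the lower number.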